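Two propargylamines at the assay limit, a third awaited

The source may report more compounds than this note shows. Statements on the series, on what has been measured and on what is new or still open speak of the compounds shown alone.

Measured so far:
compound 1, `C#CCN(CC)Cc1cn(-c2cc(NC(=S)NCC)ncn2)cn1`: in an assay on isolated protein for inhibition of Amine oxidase [flavin-containing] B (Homo sapiens), read by fluorescence and Amplex Red, with a stated time of 15 min (on this read-out higher numbers stand for weaker inhibition and lower numbers for stronger inhibition), compound 1 gives > 50000 nM, a limit of the assay rather than a number.
compound 2, `C#CCN(Cc1ccccc1)Cc1cn(-c2cc(NC(=S)NCC)ncn2)cn1`: in this assay compound 2 gives > 50000 nM, likewise a limit and not a number.

Going by the values given here, compound 2 thus stands at the edge of what the assay can report, and the only other value shown sits at the same edge, as the limit of > 50000 nM in this assay, at which 2 of the 2 values shown sit, records. Among the compounds with values here, the single measured step, a step that the two limits leave unreadable from compound 1 to compound 2, cannot be read in either direction, so it tells nothing about how a change on the saturated chain carbon bound to the amine nitrogen shifts potency.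

Compound 3, `C#CCN(CC#C)Cc1cn(-c2cc(NC(=S)NCC)ncn2)cn1`, is reached from compound 2 by ethynyl in place of phenyl on a saturated chain carbon bound to an amine nitrogen. Within the data shown here, no measured step bears on this change in a readable way, so the expectation rests on the two limits alone. Compound 3 is therefore expected to give about 50000 nM, with a range from 10000 nM to 200000 nM. The step expected from compound 2 is a number no higher from compound 2 to compound 3 (the limit leaves the size open), which most likely means another limit rather than a number.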

Compound 3, half-maximal inhibitory concentration: > 50000 nM
Compound 3: only a limit was reported (the forecaster's own chance of this, stated with the estimate: 70%); the middle value lies on the limit itself.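

Compound 3 also gives a limit of the assay and not a number, so its steps from compound 1 and from compound 2 cannot be read. Compound 1, compound 2 and compound 3 share one edge: the limit of > 50000 nM in this assay, at which 3 of the 3 values shown sit. The compounds shown leave open whether methyl, phenyl or ethynyl on this chain carbon changes potency at all.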